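Flipping One Double Bond in a Growth Inhibition Series

A few compounds are considered here, and "the series" means these few. Any claim that something is new, unique, unknown or untested is made for them only; others in the source may bear on it.

In a functional assay on the whole organism for cytotoxicity, with Homo sapiens as the target (a lower number here means a stronger inhibitor of growth, a higher number a weaker inhibitor of growth), compound 1 `CCCCCCn1c(=O)oc2ccc(NCc3cc(O)ccc3O)cc2c1=O` gives 3200 nM, while compound 2 `Oc1ccc(O)c(CNc2ccc(O)c(/C=C\CCc3ccccc3)c2)c1` gives 15900 nM, the higher of the two numbers and beyond the scatter. Compound 3 `Oc1ccc(O)c(CNc2ccc(O)c(/C=C/CCc3ccccc3)c2)c1` has not yet been measured and departs from compound 2 only in geometry: the two compounds have the same atoms and bonds and differ only in configuration as drawn: 1 of 1 stereo elements differ; a double bond is drawn Z in compound 2 and E in compound 3. Among the measured compounds shown here, no two measured compounds differ in a single place, so the data offer no precedent for this change. The estimated step is a 1.3-fold lower number from compound 2 to compound 3 (0.12 log units; within the scatter), and it is not expected to go beyond the scatter. For compound 3 the estimated value is 12000 nM, with an expected range of 4000 nM to 40000 nM.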

Compound 3, concentration for 50% growth inhibition: 18000 nM
Beside the measured number, compound 3's estimate is 1.5-fold (0.18 log units) below it, and the stated range covers the measured number.
By their numbers in this assay, from the lowest: compound 1; then compounds 2 and 3 (each within the scatter of the next).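

In this assay, among the compounds shown here, the step is a 1.1-fold higher number from compound 2 to compound 3 (0.05 log units; within the scatter), the first comparison here that isolates a single change: the fact that compounds 2 and 3 differ only in the configuration as drawn. For this pair, then, whether the double bond is Z or E makes no difference beyond the scatter. This holds only for this chain on this core.

Going by these compounds, it remains open how a fully saturated chain in place of the double bond would read in this assay. Also open, on these data alone, is whether a chain ending in an amine or a carboxylic acid would move the number beyond the scatter.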